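Compound 1 to Compound 3: Isobutyl Becomes Benzyl

A few compounds are considered here, and "the series" means these few. Any claim that something is new, unique, unknown or untested is made for them only; others in the source may bear on it.

- Compound 1 `CC(C)CN1C(=O)C=C(Cl)C1(O)c1ccccc1`: 536 nM
- Compound 2 `CC(C)CN1C(=O)C=C(Cl)C1(O)c1ccc(Cl)cc1`: 526 nM

Going by the values given here, in a functional assay on MAC13 cells (Mus musculus) for antiproliferative activity, read by MTT assay, with a stated time of 3 days (on this read-out lower numbers stand for stronger inhibition and higher numbers for weaker inhibition), compound 1 is one of only two measured compounds, and the step between them, a 1.0-fold lower number from compound 1 to compound 2 (0.01 log units; within the scatter), lies within the scatter. Compound 3 `O=C1C=C(Cl)C(O)(c2ccccc2)N1Cc1ccccc1` awaits measurement. It differs from compound 1 by phenyl in place of isopropyl on a saturated chain carbon bound to an amide-type nitrogen in a ring, isobutyl becoming benzyl. Among the compounds with values here, the single measured step, chloro in place of hydrogen on an aromatic carbon, concerns another place and offers only weak guidance. No change beyond the scatter is expected in either direction, so the expected step is a 1.2-fold lower number from compound 1 to compound 3 (0.08 log units; within the scatter). For compound 3 the estimated value is 450 nM, with an expected range of 150 nM to 1400 nM.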

Compound 3, half-maximal inhibitory concentration: > 1000 nM
Compound 3: no number, only a limit; the forecaster's own chance of this, stated with the estimate: 3%; middle value at least 2.2-fold (0.34 log units) away from the limit.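

Compound 3 carries a limit of the assay and not a number: the limit of > 1000 nM in this assay, at which 1 of the 3 values shown sits.

Phenyl in place of isopropyl on a saturated chain carbon bound to an amide-type nitrogen in a ring gives an at least 1.8-fold higher number from compound 1 to compound 3 (0.27 log units; that floor lies within the scatter). This is the first change shown that points toward weaker inhibition in this assay, although its true size stays unknown and its floor alone does not exceed the usual scatter.

As far as these compounds go, whether this position would tolerate a longer chain, or a chain ending in an amine or a carboxylic acid, remains open. So does whether the isobutyl group itself matters.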